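The source may report more compounds than this note shows. Statements on the series, on what has been measured and on what is new or still open speak of the compounds shown alone.

Compound 1 `CCCCCCCCCCCCNC(=O)[C@@H](NS(=O)(=O)c1ccc(C)cc1)[C@@H](C)O` gives 31600 nM in a functional assay on SiHa cells (Homo sapiens) for cytotoxicity, read by MTT assay, with a stated time of 48 h; on this read-out lower numbers stand for stronger inhibition and higher numbers for weaker inhibition. Among the compounds with values here, compound 2 `CCCCCCCCCCCCCCNC(=O)[C@@H](NS(=O)(=O)c1ccc(C)cc1)[C@@H](C)O` gives 19200 nM in this assay; this is the lower of the two numbers so far, and a 1.6-fold lower number from compound 1 to compound 2 (0.22 log units; within the scatter) is the only measured step. Compound 3 `CCCCCCCCCCCCCCNC(=O)[C@@H](NS(=O)(=O)c1ccc2ccccc2c1)[C@@H](C)O` differs from compound 2 by naphthalen-2-yl in place of 4-methylphenyl on a sulfonyl sulfur. Within the data shown here, no measured step touches the sulfonyl side of the core; the single step concerns the chain end and lies within the scatter, so it gives no guidance here. Among the measured compounds shown here, with no bearing precedent, no change beyond the scatter is expected in this assay, and the step is estimated as a 1.2-fold lower number from compound 2 to compound 3 (0.08 log units; within the scatter). Compound 3 is expected to give about 16000 nM, within 5000 nM to 50000 nM.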

Compound 3, half-maximal inhibitory concentration: 11100 nM
The estimate for compound 3 lay 1.4-fold (0.16 log units) above the measured number, and the stated range covers the measured number.
By their numbers in this assay, from the lowest: compounds 3, 2 and 1 (each within the scatter of the next, the first and the last beyond it).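

On the sulfonyl sulfur, naphthalen-2-yl in place of 4-methylphenyl gives a 1.7-fold lower number from compound 2 to compound 3 (0.24 log units; within the scatter) in this assay, so a second six-membered aromatic ring leaves the number within the scatter. Within the data shown here, this is the first reading on the sulfonyl side of the core: the position takes 10 heavy atoms in place of 7 with no change beyond the scatter. No evidence at hand bears on this result.

Open, on these data alone, is whether an amine or a carboxylic acid on the aromatic ring at this sulfonyl sulfur would move the number beyond the scatter. As far as these compounds go, a longer chain on the amide nitrogen is equally open.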